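A few compounds are considered here, and "the series" means these few. Any claim that something is new, unique, unknown or untested is made for them only; others in the source may bear on it.

Measured so far:
Compound 1 `O=C1c2cc(-c3ccc(OC(F)(F)F)cc3)ccc2OCCN1Cc1ncccn1`: 24000 nM
Compound 2 `O=C1c2cc(-c3ccc(OC(F)(F)F)cc3)ccc2CCN1Cc1ncccn1`: 60000 nM

In a physicochemical assay for solubility (a higher number here means a more soluble compound, a lower number a less soluble compound), compound 2 gives 60000 nM, the higher of the two numbers. The nearest number is that of compound 1, which in this assay gives 24000 nM, and the gap between these two values lies beyond the usual scatter. Compound 3 `O=C1c2cc(-c3ccc(C(F)(F)F)cc3)ccc2CCN1Cc1ncccn1` has not yet been measured. It differs from compound 2 in one place: trifluoromethyl in place of trifluoromethoxy on an aromatic carbon. Within the data shown here, no measured pair shows this particular change, so the size of the step cannot be read from the numbers at hand. A small drop, or a step within the scatter, is expected for compound 3 in this assay, as the step of a 1.3-fold lower number from compound 2 to compound 3 (0.12 log units; within the scatter) expresses. The estimate for compound 3 is 45000 nM, with a range from 20000 nM to 110000 nM.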

Compound 3, solubility: 28000 nM
Estimate against measurement, compound 3: 1.6-fold (0.21 log units) above; measured number inside the range.
By their numbers in this assay, from the lowest: compounds 1 and 3 (each within the scatter of the next); then compound 2.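

Replacing trifluoromethoxy with trifluoromethyl on an aromatic carbon of the six-membered aromatic ring of carbon only, para to a large group, gives a 2.1-fold lower number from compound 2 to compound 3 (0.33 log units; beyond the scatter) in this assay. Among these compounds, this is the first step read at this position, and it shows that the number responds to the substituent there, modestly but beyond the scatter. The group that enters differs from the one that leaves by the oxygen and its hydrogen-bond acceptor, yet nothing at hand accounts for the step.

The compounds shown leave open how the number would move with another group on this carbon, such as a nitrile, a morpholine or a carboxylic acid. They also leave open whether the same change would give a similar step on the core of compound 1.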